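Working notes: cytotoxicity across compounds 1 to 3

The source may report more compounds than this note shows. Statements on the series, on what has been measured and on what is new or still open speak of the compounds shown alone.

Measured so far:
compound 1, `CC(C)(C)OC(=O)c1cccc(NC(=O)C2CCCN(C(=O)c3cc(C(F)(F)F)cc(C(F)(F)F)c3)C2)c1`: 0%
compound 2, `C=CCOc1cccc(NC(=O)C2CCCN(C(=O)c3cc(C(F)(F)F)cc(C(F)(F)F)c3)C2)c1`: 0%

In an ADME assay on PC-3 cells (Homo sapiens) for cytotoxicity, read by WST assay, tested at 100 uM (on this read-out higher numbers stand for more inhibition at the one concentration tested (going by the name of the read-out) and lower numbers for less inhibition), compound 1 gives 0% and compound 2 gives 0%. Within the data shown here, the one step inside the measured set, no change at the digits printed from compound 1 to compound 2 (within the scatter), puts allyloxy in place of tert-butoxycarbonyl on an aromatic carbon and leaves the read-out unchanged within the scatter. Compound 2 therefore stands level with compound 1 at the digits shown; neither shows any inhibition at the single concentration tested.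

Compound 3, `COc1cccc(NC(=O)C2CCCN(C(=O)c3cc(C(F)(F)F)cc(C(F)(F)F)c3)C2)c1`, is the next member. It differs from compound 2 as follows: hydrogen in place of vinyl on a saturated chain carbon bound to an oxygen on an aromatic ring; read one bond further out, the change is allyloxy to methoxy. Among the measured compounds shown here, the only step that bears on it is no change at the digits printed from compound 1 to compound 2 (within the scatter), which swapped the whole substituent on that aromatic carbon without any movement in this assay. Trimming the ether from allyl to methyl is a smaller change at the same position, so no step beyond the scatter is expected, and the step from compound 2 to compound 3 is estimated as no change at the digits printed from compound 2 to compound 3 (within the scatter).

The expected value for compound 3 in this assay is 0%, with a range from 0% to 12%.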

Compound 3, a percentage reported as inhibition, at one concentration (the size of the read-out at that concentration, not a potency): 0%
Beside the measured number, compound 3's estimate shows no gap at the digits printed, and the stated range covers the measured number.
By their numbers in this assay, from the lowest: compounds 1, 2 and 3 (each within the scatter of the next).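

In this assay the ether at this aromatic carbon can be cut from allyl to methyl with no change at the digits printed from compound 2 to compound 3 (within the scatter) as the outcome, so the length of the ether chain now joins the swap of the whole substituent as a change that leaves the read-out in place. Methoxy in place of tert-butoxycarbonyl gives no change at the digits printed from compound 1 to compound 3 (within the scatter) as well, which means that three different substituents at this one place, two ethers and one ester, now share a reading of no inhibition at the single concentration tested. Nothing available explains this flat result.

All three compounds sit at the bottom of the read-out, so the series gives no ranking here and does not show what, if anything, at this aromatic carbon would raise the inhibition. As far as these compounds go, an amine or a carboxylic acid at that place, a longer chain on the ether, and any change elsewhere on the shared core all remain open, and a single-concentration read-out gives no potency for any of them.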